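The source may hold more compounds than are shown below. What is called first, only, known or untested is meant among the compounds shown, and "the series" means these compounds.

Compound 1 `Cc1ccccc1-n1nc(-c2ccccc2)nc1CNc1ccc(C(=O)NO)cc1` gives 57.1% in an assay on Sf9 cells for inhibition of protein deacetylase HDAC6 (Homo sapiens), read by fluorescence, with a stated time of 40 min, tested at 100 nM; on this read-out lower numbers stand for less inhibition and higher numbers for more inhibition at the one concentration tested (going by the name of the read-out).
Compound 2 `O=C(NO)c1ccc(NCc2nc(-c3ccccc3)nn2-c2ccc(F)cc2)cc1` gives 67.6% in this assay.
Compound 3 `CCc1ccc(-n2nc(-c3ccccc3)nc2CNc2ccc(C(=O)NO)cc2)cc1` gives 38.3% in this assay.

Compound 3 gives the lowest of the three numbers; compound 1 sits nearest to it and compound 2 furthest, both beyond the scatter. Compound 4 `O=C(NO)c1ccc(NCc2nc(-c3ccccc3)nn2-c2ccccc2Cl)cc1` differs from compound 3 in one place: 2-chlorophenyl in place of 4-ethylphenyl on an aromatic nitrogen. For the measured compounds named here, two measured steps bear on this swap. The step of a number 18.8 percentage points lower from compound 1 to compound 3 (beyond the scatter) shows that going from the 2-methylphenyl of compound 1 to 4-ethylphenyl lowered inhibition, and a number 29.3 percentage points lower from compound 2 to compound 3 (beyond the scatter) shows the same direction starting from the halogen-bearing 4-fluorophenyl of compound 2. The 2-chlorophenyl of compound 4 resembles both of those groups more than it resembles 4-ethylphenyl, so a rise in this assay is expected, roughly undoing a number 18.8 percentage points lower from compound 1 to compound 3 (beyond the scatter). Compound 4 is therefore expected to give 58%, between 42% and 74%, an expected step of a number 19.7 percentage points higher from compound 3 to compound 4 (beyond the scatter).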

Compound 4, a percentage reported as inhibition, at one concentration (the size of the read-out at that concentration, not a potency): 64.6%
Compound 4: the middle estimate sits 6.6 percentage points below what was measured; low and high end bracket the measured number.
By their numbers in this assay, from the lowest: compound 3; then compounds 1, 4 and 2 (each within the scatter of the next, the first and the last beyond it).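

In this assay, 2-chlorophenyl on the aromatic nitrogen gives a number 26.3 percentage points higher from compound 3 to compound 4 (beyond the scatter), so the low number belongs to 4-ethylphenyl and not to every substituted phenyl here. Against the other two groups, the steps are a number 3 percentage points lower from compound 2 to compound 4 (within the scatter) and a number 7.5 percentage points higher from compound 1 to compound 4 (within the scatter), so compound 4 cannot be ranked against either, even though compounds 1 and 2 differ beyond the scatter. Nothing measured here explains these differences. Still open, on these data alone, is how a phenyl ring carrying an amine or a carboxylic acid would behave at this position.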